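Substituent on the ring nitrogen: hydroxyalkyl chain to hydroxyaryl

The source may report more compounds than this note shows. Statements on the series, on what has been measured and on what is new or still open speak of the compounds shown alone.

In a functional assay on RT-112 cells (Homo sapiens) for antiproliferative activity, read by MTT assay, with a stated time of 3 h (on this read-out higher numbers stand for weaker inhibition and lower numbers for stronger inhibition), compound 1 `C#CCNc1nc(-c2ccccc2)c(Cc2c(O)ccc3ccccc23)c(=O)[nH]1` gives 91200 nM and compound 2 `O=c1[nH]c(NCCO)nc(-c2ccccc2)c1Cc1c(O)ccc2ccccc12` gives 7200 nM, the lower of the two numbers measured. Among the measured compounds shown here, the single measured step, a 13-fold lower number from compound 1 to compound 2 (1.10 log units; beyond the scatter), shows that the group on this nitrogen moves the read-out strongly. Compound 3 `O=c1[nH]c(Nc2ccc(O)cc2)nc(-c2ccccc2)c1Cc1c(O)ccc2ccccc12` carries 4-hydroxyphenyl in place of 2-hydroxyethyl on a nitrogen on an aromatic ring. For the measured compounds named here, no measured step exchanges a chain for an aromatic ring on this nitrogen, so the direction of the change cannot be read from the data. A small step is expected, a 1.4-fold lower number from compound 2 to compound 3 (0.16 log units; within the scatter), with wide uncertainty in either direction. Compound 3 is estimated at 5000 nM, within 1200 nM to 25000 nM.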

Compound 3, half-maximal inhibitory concentration: > 300000 nM
Compound 3 was reported as a limit; the forecaster's own chance of this, stated with the estimate: 5%; middle value at least 60-fold (1.77 log units) away from the limit.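

Compound 3 stands at a limit in this assay: the limit of > 300000 nM in this assay, at which 1 of the 3 values shown sits. On this nitrogen, 4-hydroxyphenyl in place of 2-hydroxyethyl gives an at least 41-fold higher number from compound 2 to compound 3 (1.61 log units; beyond the scatter), so a hydroxyl carried on both groups does not by itself hold the read-out. In place of propargyl, the same ring gives an at least 3.2-fold higher number from compound 1 to compound 3 (0.51 log units; beyond the scatter), so both chains shown give lower numbers than this aromatic ring.

Open, on these data alone, is whether a longer hydroxyalkyl chain, a terminal amine or a benzyl group on this nitrogen would lower the number further or raise it. Also open, as far as these compounds go, is whether the rise with 4-hydroxyphenyl belongs to the ring itself or to its hydroxyl.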